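The source may report more compounds than this note shows. Statements on the series, on what has been measured and on what is new or still open speak of the compounds shown alone.

Compound 1, with the structure `COc1cc(C[C@@H]2C(=O)OC[C@H]2[C@@H](O[C@@H]2O[C@H](CO)[C@@H](O)[C@H](O)[C@H]2O)c2ccc(O)c(OC)c2)ccc1O`, is a sugar-bearing lignan-type molecule. In a functional assay on SK-OV-3 cells (Homo sapiens) for cytotoxicity, read by sulforhodamine B assay, with a stated time of 48 h (a higher number here means a weaker inhibitor, a lower number a stronger inhibitor), compound 1 reaches only the limit of the measurement, giving > 10000 nM. Compound 2, with the structure `COc1cc(C[C@@H]2C(=O)OC[C@H]2[C@@H](O)c2ccc(O[C@@H]3O[C@H](CO)[C@@H](O)[C@H](O)[C@H]3O)c(OC)c2)ccc1O`, carries the sugar on a different oxygen of the shared core. In this assay compound 2 likewise sits at the limit, with > 10000 nM. So both values on record are limits rather than numbers: the limit of > 10000 nM in this assay, at which 2 of the 2 values shown sit. Compound 3, with the structure `COc1cc(C[C@@H]2C(=O)OC[C@H]2[C@@H](O)c2cc(OC)c(O[C@@H]3O[C@H](CO)[C@@H](O)[C@H](O)[C@H]3O)c(OC)c2)ccc1O`, differs from compound 2 by methoxy in place of hydrogen on an aromatic carbon, a methoxy in place of hydrogen on an aromatic carbon. Among the compounds with values here, with no measured step to lean on, the change from compound 2 to compound 3 is expected to bring no shift beyond the scatter, giving a number no higher from compound 2 to compound 3 (the limit leaves the size open). Compound 3 is therefore expected again to land around the limit, estimated at 10000 nM, within a range from 5000 nM to 40000 nM.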

Compound 3, half-maximal inhibitory concentration: > 10000 nM
Compound 3: a limit, no number; the forecaster's own chance of this, stated with the estimate: 85%; the middle value sits exactly at the limit.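

In this assay, within the data shown here, compound 3 gives > 10000 nM, which is a limit and not a number, so no step from compound 2 to compound 3 can be read. The compounds shown leave open how strongly any of them acts and what the methoxy changes, as all share one result: the limit of > 10000 nM in this assay, at which 3 of the 3 values shown sit.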